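A few compounds are considered here, and "the series" means these few. Any claim that something is new, unique, unknown or untested is made for them only; others in the source may bear on it.

Compound 1 `C#CCSc1nc(Nc2cccc(C(F)(F)F)c2)c(C#N)c(-c2ccccc2)n1`: > 128000 nM, which is a limit of the assay and not a number.
Compound 2 `C#CCSc1nc(Nc2ccc(Cl)cc2)c(C#N)c(-c2ccccc2)n1`: > 128000 nM, again a limit rather than a number.
Compound 3 `N#Cc1c(Nc2ccc(Cl)cc2)nc(SCc2cn(Cc3ccccc3Cl)nn2)nc1-c1ccccc1`: 1420 nM.

For the measured compounds named here, in a functional assay on ECa-109 cells (Homo sapiens) for inhibition, read by MTT assay, with a stated time of 72 h (a lower number here means a stronger inhibitor, a higher number a weaker inhibitor), compound 3 gives 1420 nM, and this is the only actual number among the three values shown. The other two values sit at the limit of > 128000 nM in this assay, at which 2 of the 3 values shown sit. Going by the values given here, since compound 3 alone has a number, no step between two measured compounds can be drawn, and where compound 3 stands can be said only this far: it is the one compound of the three that yields a readable half-maximal inhibitory concentration in this assay.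

Compound 4 `N#Cc1c(Nc2ccccc2F)nc(SCc2cn(Cc3ccccc3Cl)nn2)nc1-c1ccccc1` differs from compound 3 in one place: 2-fluorophenyl in place of 4-chlorophenyl on a nitrogen on an aromatic ring. Among the compounds with values here, both groups carry one halogen on a phenyl ring, and nothing among the measured compounds tells how this exchange shifts potency; the two limit values give no guidance. The step is therefore expected to be small, likely within the scatter, with no direction preferred. Compound 4 is estimated at 2000 nM, within 500 nM to 8000 nM. The expected step from compound 3 to compound 4 is thus a 1.4-fold higher number from compound 3 to compound 4 (0.15 log units; within the scatter).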

Compound 4, half-maximal inhibitory concentration: 23000 nM
Compound 4: middle estimate off by 12-fold (1.06 log units), on the low side, and the stated range ends below it.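

In this assay, the exchange of 4-chlorophenyl for 2-fluorophenyl on a nitrogen on an aromatic ring is far from neutral, giving a 16-fold higher number from compound 3 to compound 4 (1.21 log units; beyond the scatter), even though the two groups match in their count of heavy atoms. Compound 1 and compound 2 also differ in this place, but each of their values is a limit of the assay and not a number, so they gave no size for a change here. Nothing measured among the compounds shown gives a reason for this step.

The change alters the halogen and its place on the ring together, and neither 2-chlorophenyl nor 4-fluorophenyl stands here to separate the two. Also open, going by these compounds, is how an unsubstituted phenyl or a 4-methoxyphenyl would read in this place.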